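Chloro Added to Compound 3: Expected Cell Toxicity

The source may hold more compounds than are shown below. What is called first, only, known or untested is meant among the compounds shown, and "the series" means these compounds.

Compound 1 `O=C(Nc1cccc(-n2cc(-c3ccncc3)c(-c3ccc(Cl)c(O)c3)n2)c1)Nc1cccc(C(F)(F)F)c1` gives in a functional assay on SNB-19 cells (Homo sapiens) for inhibition, read by sulforhodamine B assay, with a stated time of 48 h (on this read-out lower numbers stand for higher toxicity in this test and higher numbers for lower toxicity in this test), only a limit, > 32500 nM.
Compound 2 `COc1cc(-c2nn(-c3cccc(NC(=O)c4cccc(C(F)(F)F)c4)c3)cc2-c2ccncc2)ccc1Cl` gives in this assay only a limit, > 50000 nM.
Compound 3 `COc1cc(-c2nn(-c3cccc(NC(=O)Nc4cccc(C(F)(F)F)c4)c3)cc2-c2ccncc2)ccc1Cl` gives in this assay only a limit, > 50000 nM.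

Compound 3 therefore stands nowhere in particular among these numbers: its result in this assay is a limit, and the two other results shown are limits as well. The two changes that lead to compound 3 from measured neighbours, a step that the two limits leave unreadable from compound 1 to compound 3 and a step that the two limits leave unreadable from compound 2 to compound 3, cannot be sized, because both ends rest on a limit, as the limit of > 32500 nM in this assay, at which 1 of the 3 values shown sits, and the limit of > 50000 nM in this assay, at which 2 of the 3 values shown sit, record.

Compound 4 `COc1cc(-c2nn(-c3cccc(NC(=O)Nc4ccc(Cl)c(C(F)(F)F)c4)c3)cc2-c2ccncc2)ccc1Cl` differs from compound 3 by chloro in place of hydrogen on an aromatic carbon. Within the data shown here, no measured step bears directly on this change; all that the three measured compounds show is that none of them reached a measurable toxicity in this assay. The expectation for the step from compound 3 to compound 4 in this assay is accordingly a step that the limit leaves unreadable from compound 3 to compound 4, that is, no readable change. For compound 4 the estimated result in this assay is 60000 nM, with a range from 20000 nM to 200000 nM, and most likely the assay will again report only a limit.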

Compound 4, concentration lethal to 50% of the cells: > 32500 nM
Compound 4 ended at the assay's limit; the forecaster's own chance of this, stated with the estimate: 80%; the middle value is on the limit's open side.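

Compound 4 gives only a limit in this assay, as do compound 2 and compound 3, so no new step can be read from either of them to compound 4. The compounds shown leave open whether chloro in place of hydrogen changes toxicity in this assay at all, since none of the four has a measured number there.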